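The source may hold more compounds than are shown below. What is called first, only, known or untested is meant among the compounds shown, and "the series" means these compounds.

Measured so far:
compound 1 `Cc1c(Oc2cnc(C(=O)NCCO)cn2)ccc2c1B(O)OC2` gives 31400 ng.h/mL
compound 2 `CCC[C@H](CO)NC(=O)c1cnc(Oc2ccc3c(c2C)B(O)OC3)cn1` gives 20500 ng.h/mL

In an ADME assay on the whole organism (strain CD1) for pharmacokinetics, with Mus musculus as the target, read by LC-MS, at a dose of 5 mg/kg by the intravenous route (on this read-out lower numbers stand for lower exposure and higher numbers for higher exposure at the dose given), compound 2 gives 20500 ng.h/mL and lies within the scatter of compound 1 so no order can be read between the two. Compound 3 `Cc1c(Oc2cnc(C(=O)N[C@@H](CO)CC(F)(F)F)cn2)ccc2c1B(O)OC2` differs from compound 2 by trifluoromethyl in place of ethyl on a saturated chain carbon, two bonds along the chain from an amide-type nitrogen and this is trifluoromethyl in place of ethyl on a saturated chain carbon, two bonds along the chain from an amide-type nitrogen. Cut one bond further out, the same difference reads propyl to 2,2,2-trifluoroethyl. Among the measured compounds shown here, the one measured step that bears on this is a 1.5-fold lower number from compound 1 to compound 2 (0.19 log units; within the scatter) and it is the step that brings in that propyl. It stays within the scatter for the whole group. For the measured compounds named here, no measured compound carries a trifluoromethyl group, so this evidence is indirect. No step beyond the scatter is therefore expected in this assay and no direction is favoured. The expected step is a 1.2-fold higher number from compound 2 to compound 3 (0.07 log units; within the scatter) and this estimate lies within the scatter. For compound 3 the estimated value is 24000 ng.h/mL with an expected range from 11000 ng.h/mL to 50000 ng.h/mL on this read-out.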

Compound 3, area under the concentration-time curve: 21000 ng.h/mL
Compound 3: middle estimate off by 1.1-fold (0.06 log units), on the high side; measured number inside the range.
By their numbers in this assay, from the lowest: compounds 2, 3 and 1 (each within the scatter of the next).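

In this assay, trifluoromethyl in place of ethyl on a saturated chain carbon, two bonds along the chain from an amide-type nitrogen, gives a 1.0-fold higher number from compound 2 to compound 3 (0.01 log units; within the scatter), the first measured change made within the substituent itself rather than by adding one, and no difference can be read from it. Swapped for hydrogen, 2,2,2-trifluoroethyl gives a 1.5-fold lower number from compound 1 to compound 3 (0.17 log units; within the scatter), so alongside a 1.5-fold lower number from compound 1 to compound 2 (0.19 log units; within the scatter), neither propyl nor 2,2,2-trifluoroethyl at this carbon separates from the hydrogen of compound 1 in this read-out, and none of the three compounds goes against that. No measurement at hand accounts for this flat picture.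

Whether any group at this carbon can move the number beyond the scatter stays open, since a carboxylic acid, an amine or a longer chain such as hexyl is absent from the compounds shown. Also open, as far as these compounds go, is what the hydroxymethyl part contributes, as all three compounds keep a hydroxyl group and none shows a methoxy or an amino group in its place.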